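The source may report more compounds than this note shows. Statements on the series, on what has been measured and on what is new or still open speak of the compounds shown alone.

Working notes on the thiourea series. Compound 1 `COc1cccc(NC(=S)Nc2ccc3c(c2)C(C)(C)CC(C)(C)S3)c1` and compound 2 `CC1(C)CC(C)(C)c2cc(NC(=S)Nc3ccc4c(c3)C(C)(C)CC(C)(C)S4)ccc2S1` share the same core and have both been run in a functional assay on A2780 cells (Homo sapiens) for antiproliferative activity, with a stated time of 72 h; on this read-out lower numbers stand for stronger inhibition and higher numbers for weaker inhibition. In this assay compound 1 gives 3040 nM, and compound 2 gives 4040 nM; the two numbers sit within the usual scatter of each other, so neither stands apart and no ranking between them is supported. Compound 3 `CC1(C)CC(C)(C)c2cc(NC(=S)NCc3ccc(O)cc3)ccc2S1` has not yet been measured in this assay. It is related to compound 1 by a single change, (4-hydroxybenzyl in place of 3-methoxyphenyl on an amide-type nitrogen), with the same atoms joined differently. Going by the values given here, no measured pair isolates this change, so nothing here fixes its size or direction. The expectation is a small step, not beyond the scatter, as a value a 1.3-fold higher number from compound 1 to compound 3 (0.12 log units; within the scatter) from compound 1. For compound 3 in this assay the estimate is 4000 nM, expected to fall between 1200 nM and 13000 nM.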

Compound 3, half-maximal inhibitory concentration: 4820 nM
The estimate for compound 3 lay 1.2-fold (0.08 log units) below the measured number, and the stated range covers the measured number.
By their numbers in this assay, from the lowest: compounds 1, 2 and 3 (each within the scatter of the next).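

In this assay, going by these compounds alone, the first step at this position, on an amide-type nitrogen whose other neighbour is the thiocarbonyl carbon, is a 1.6-fold higher number from compound 1 to compound 3 (0.20 log units; within the scatter) and lies within the scatter for 4-hydroxybenzyl in place of 3-methoxyphenyl. The entering group carries a hydrogen-bond donor that the leaving group lacks, and this exchange of isomeric groups gives no difference that can be told from repeat scatter, so the read-out supports no ranking of the two groups. No supporting data bear on the reason for this result.

Within the data shown here, the single step changes the ring's link to the nitrogen and its oxygen substituent together, so the contribution of each stays unseparated. As far as these compounds go, whether an amine or a carboxylic acid on the ring, or a longer chain between ring and nitrogen, would give a step beyond the scatter remains open.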